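A few compounds are considered here, and "the series" means these few. Any claim that something is new, unique, unknown or untested is made for them only; others in the source may bear on it.

Compound 3 `Cn1c(CCc2ccccc2)nc2cc(Cl)c(Cl)cc21` is measured in a functional assay on HepG2 cells (Homo sapiens) for cytotoxicity (a lower number here means that less compound is tolerated, a higher number that more compound is tolerated), where compound 3 gives 15300 nM. Compound 1 `Cc1ccc(S(=O)(=O)n2c(CCCN3C(=O)c4ccccc4C3=O)nc3cc(Cl)c(Cl)cc32)cc1` gives 13000 nM in this assay, a number within the scatter of that of compound 3, so the two cannot be told apart. Compound 2 `Cn1c(CCC2CCCCC2)nc2cc(Cl)c(Cl)cc21` is reported in this assay only as a limit, > 500000 nM. Compound 4 `Cn1c(CCc2ccncc2)nc2cc(Cl)c(Cl)cc21` has not yet been measured; it differs from compound 3 by pyridin-4-yl in place of phenyl on a saturated chain carbon, two bonds along the chain from an aromatic carbon. For the measured compounds named here, one measured step touches the same chain position: an at least 32-fold lower number from compound 2 to compound 3 (1.51 log units; beyond the scatter), a saturated ring giving way to an aromatic one, starting from the limit of > 500000 nM in this assay, at which 1 of the 3 values shown sits. Going by the values given here, the step to compound 4 keeps a six-membered aromatic ring in place and exchanges phenyl for pyridin-4-yl, so no step of that size is expected; the number for compound 4 is expected to shift modestly upward, barely beyond the scatter, an estimated 2.0-fold higher number from compound 3 to compound 4 (0.29 log units; within the scatter). Compound 4 is therefore estimated at 30000 nM, with a range from 9000 nM to 110000 nM.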

Compound 4, half-maximal cytotoxic concentration: 35800 nM
Beside the measured number, compound 4's estimate is 1.2-fold (0.08 log units) below it; the measured number falls inside the stated range.
By their numbers in this assay, from the lowest: compounds 1 and 3 (each within the scatter of the next); then compound 4. At a limit, above all of these: compound 2.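

In this assay the exchange of one six-membered aromatic ring for another on this chain carbon proves detectable on its own: there is a 2.3-fold higher number from compound 3 to compound 4 (0.37 log units; beyond the scatter), a modest change beyond the scatter, with a single ring nitrogen and its one hydrogen-bond acceptor as the only difference. The large gap to the saturated ring, first seen with phenyl, also holds for pyridin-4-yl, with an at least 13-fold lower number from compound 2 to compound 4 (1.14 log units; beyond the scatter), so both aromatic rings stand well apart from cyclohexyl. That gap has only a lower bound, as compound 2 is a limit and not a number: the limit of > 500000 nM in this assay, at which 1 of the 4 values shown sits. The compounds shown leave open whether pyridin-3-yl or pyridin-2-yl would match pyridin-4-yl at this position. They also leave open how an amine or a carboxylic acid on the ring, or a longer chain, would move the number.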